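Replacing Hydroxymethyl in a Set Resting at Its Limit

The source may report more compounds than this note shows. Statements on the series, on what has been measured and on what is new or still open speak of the compounds shown alone.

Of the compounds shown here, three built on a shared core have been tested in a functional assay on Raji cells (Homo sapiens) for cytotoxicity, with a stated time of 72 h; a higher number here means that more compound is needed for the effect, a lower number that less compound is needed. Compound 1 (`C=C[C@@](C)(/C=C/c1ccc(OS(=O)(=O)c2ccc(C)cc2)cc1)CCC=C(C)C`) gives > 26000 nM, which is a limit of the assay and not a number. Compound 2 (`C=C[C@@](C)(/C=C/c1ccc(O)cc1)CCC(O)C(C)(C)O`) gives > 26000 nM, again a limit. Compound 3 (`C=C[C@@](C)(/C=C/c1ccc(O)c(CO)c1)CCC=C(C)C`) gives > 26000 nM, also a limit. Compound 3 therefore has no number of its own, and the whole set rests on (the limit of > 26000 nM in this assay, at which 3 of the 3 values shown sit).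

Compound 4 (`C=C[C@@](C)(/C=C/c1ccc(O)c(/C=C/C(=O)OCC)c1)CCC=C(C)C`) carries 2-(ethoxycarbonyl)ethenyl in place of the hydroxymethyl of compound 3, on an aromatic carbon ortho to a hydroxy group: 2-(ethoxycarbonyl)ethenyl in place of hydroxymethyl on an aromatic carbon. Among the compounds with values here, no measured step offers a guide to this change, so no shift beyond the usual scatter is expected in this assay. The expected change is an at least 1.1-fold lower number from compound 3 to compound 4 (0.07 log units; that floor lies within the scatter), an estimate that stays within that scatter. For compound 4 the estimated half-maximal effective concentration is 22000 nM, with an expected range from 9000 nM to 40000 nM.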

Compound 4, half-maximal effective concentration: > 26000 nM
Compound 4: only a limit was reported; the forecaster's own chance of this, stated with the estimate: 65%; at least 1.1-fold (0.07 log units) between middle value and limit.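

In this assay compound 4 gives > 26000 nM, a limit and not a number. Compound 3 also rests at a limit, so the change between compound 3 and compound 4 cannot be read as a step. The compounds shown leave open whether any change to the shared core would bring a readable number, as the whole set rests on one limit: the limit of > 26000 nM in this assay, at which 4 of the 4 values shown sit.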